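Two Measured Diaryl Pyridine Phenols and One Untested Analogue

This account rests on a few compounds, and the source may have more. Where it says the series, first, only, none or still open, it means among the compounds named here.

Measured compounds:
compound 1 `Oc1ccc(-c2cc(-c3ccccc3F)cc(-c3cccc(O)c3)n2)cc1` — in a functional assay on HCT-15 cells (Homo sapiens) for inhibition (a lower number here means a stronger inhibitor, a higher number a weaker inhibitor), compound 1 gives 5630 nM
compound 2 `Oc1ccc(-c2cc(-c3ccccc3F)cc(-c3ccc(O)cc3)n2)cc1` — in this assay compound 2 gives 8180 nM

Within the data shown here, compound 1 sits beside compound 2 on these two numbers: the only step, a 1.5-fold higher number from compound 1 to compound 2 (0.16 log units; within the scatter), lies within the scatter, so the two cannot be told apart. Compound 3 `Oc1ccc(-c2cc(-c3ccccc3OC(F)(F)F)cc(-c3cccc(O)c3)n2)cc1` differs from compound 1 in one place: trifluoromethoxy in place of fluoro on an aromatic carbon. Among the measured compounds shown here, no measured step touches this position; the single measured step concerns the hydroxyphenyl group and says nothing about the fluoro or what replaces it. For the measured compounds named here, with no bearing step, the expectation is that the change from compound 1 to compound 3 produces no shift beyond the scatter in this assay, expressed as a 1.0-fold lower number from compound 1 to compound 3 (0.00 log units; within the scatter). Compound 3 is therefore estimated at 5600 nM, with a range from 1800 nM to 18000 nM reflecting the lack of any comparable measurement.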

Compound 3, half-maximal inhibitory concentration: 2310 nM
Compound 3: the middle estimate sits 2.4-fold (0.38 log units) above what was measured; the range from low to high includes it.
By their numbers in this assay, from the lowest: compound 3; then compounds 1 and 2 (each within the scatter of the next).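

Among these compounds, this position is the first place where a single change moves the number beyond the scatter. In this assay, putting trifluoromethoxy in place of fluoro on an aromatic carbon, ortho to a large group, gives a 2.4-fold lower number from compound 1 to compound 3 (0.39 log units; beyond the scatter), so the group at this place does affect inhibition of these cells, and the larger group gives the stronger inhibitor of this pair. Nothing available explains why this exchange shifts the number.

With one exchange at this place, the compounds shown leave open whether a methoxy or a trifluoromethyl group would shift the number in the same way, and so which part of trifluoromethoxy matters. They also leave open whether the same exchange would have the same effect with the 4-hydroxyphenyl group of compound 2 in place.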